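Replacing the aromatic group of compound 2

This account rests on a few compounds, and the source may have more. Where it says the series, first, only, none or still open, it means among the compounds named here.

Measured in a functional assay on RT-112 cells (Homo sapiens) for antiproliferative activity, read by MTT assay, with a stated time of 72 h; on this read-out lower numbers stand for stronger inhibition of growth and higher numbers for weaker inhibition of growth:
- compound 1 `COc1cc(Nc2ncnc3c(NC(=O)Nc4ccccc4Cl)cccc23)cc(OC)c1`: 356 nM
- compound 2 `COc1cc(Nc2ncnc3c(NC(=O)Nc4ccc(F)cc4C(F)(F)F)cccc23)cc(OC)c1`: 2970 nM

Of these two, compound 2 stands highest at 2970 nM, so it is the weaker growth inhibitor, and the gap between them lies beyond the scatter. The next compound, compound 3 `COc1cc(Nc2ncnc3c(NC(=O)Nc4cccc(C)c4C)cccc23)cc(OC)c1`, keeps the shared core but carries 2,3-dimethylphenyl in place of 4-fluoro-2-(trifluoromethyl)phenyl on an amide-type nitrogen.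

Among the compounds with values here, one measured step bears on this change: an 8.3-fold higher number from compound 1 to compound 2 (0.92 log units; beyond the scatter). That step brought in the very group that compound 3 gives up, replacing 2-chlorophenyl at the same place. Without that group, compound 1 gives 356 nM, so a move back towards lower numbers seems more likely than no move at all. Within the data shown here, no measured compound carries 2,3-dimethylphenyl, however, so the size remains uncertain, and a full return is not assumed.

The expected change in this assay is a 3.7-fold lower number from compound 2 to compound 3 (0.57 log units; beyond the scatter), a smaller step than the measured one and towards a lower number. For compound 3 the estimated value is 800 nM, with an expected range from 250 nM to 2600 nM.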

Compound 3, concentration for 50% growth inhibition: 5910 nM
Compound 3: the middle estimate sits 7.4-fold (0.87 log units) below what was measured, outside the stated range (above it).
By their numbers in this assay, from the lowest: compound 1; then compounds 2 and 3 (each within the scatter of the next).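

In this assay, putting 2,3-dimethylphenyl in place of 4-fluoro-2-(trifluoromethyl)phenyl on the amide-type nitrogen gives a 2.0-fold higher number from compound 2 to compound 3 (0.30 log units; within the scatter), so these two groups cannot be told apart here, although one carries fluorine and the other only carbon. Measured against 2-chlorophenyl, the same 2,3-dimethylphenyl group gives a 17-fold higher number from compound 1 to compound 3 (1.22 log units; beyond the scatter), and with an 8.3-fold higher number from compound 1 to compound 2 (0.92 log units; beyond the scatter) this shows that both replacements of 2-chlorophenyl leave a weaker growth inhibitor, so among these three compounds the loss is not tied to the fluorinated group alone and compound 1 is the strongest. Nothing available here accounts for this pattern.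

The compounds shown leave open whether the advantage of compound 1 belongs to its chlorine or to having only one group on the aromatic ring, a question that plain phenyl, 2-methylphenyl or 2-bromophenyl at this place would help to answer. They also leave open whether an aromatic ring is needed here at all, since neither a cyclohexyl group nor a short chain such as ethyl is among them.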